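The compounds below may be only part of what the source reports. "The series", "measured", "known", "first", "only" and "open" are said of these compounds alone.

Working notes on the series. Compound 1 `CC(=O)OC(C)n1cnc2c(Cl)nc(N)nc21` and compound 2 `CC(=O)OC(C)n1cnc2c(Cl)nc(F)nc21` share one core; compound 3 `CC(=O)OCCOn1cnc2c(S)nc(N)nc21` and compound 4 `CC(=O)OCCOn1cnc2c(S)nc(F)nc21` share another, and the difference between the two cores is not broken down here. All numbers come from a functional assay on CCRF-CEM cells (Homo sapiens) for inhibition; on this read-out lower numbers stand for stronger inhibition and higher numbers for weaker inhibition.

In this assay compound 1 gives only > 500000 nM, which is a limit of the assay and not a number. Compound 2 gives 44000 nM. The step of an at least 11-fold lower number from compound 1 to compound 2 (1.05 log units; beyond the scatter) corresponds to the change (fluoro in place of amino on an aromatic carbon), and its size is known only as a floor because of the limit of > 500000 nM in this assay, at which 1 of the 3 values shown sits. For the measured compounds named here, compound 3 gives 7500 nM, the lowest of the two numbers so far, with compound 2 the nearest measured neighbour.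

Compound 4 carries the same kind of change relative to compound 3: fluoro in place of amino on an aromatic carbon. The surroundings of the place are not identical, since in compound 3 the carbon is meta to a sulfanyl group (1 heavy atom) where in compound 1 it is meta to a chloro group (1 heavy atom), so the two changes are of the same kind rather than the same.

From compound 3 to compound 4 a step of about a 5.0-fold lower number from compound 3 to compound 4 (0.70 log units; beyond the scatter) is expected, resting on the earlier step of an at least 11-fold lower number from compound 1 to compound 2 (1.05 log units; beyond the scatter) seen with compound 1, with some allowance for the different core and the floor-only size of that earlier step. Compound 4 is therefore estimated at 1500 nM, with a range from 400 nM to 6000 nM.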

Compound 4, half-maximal inhibitory concentration: 37000 nM
For compound 4 the middle estimate is 25-fold (1.39 log units) below the measured one, outside the stated range (above it).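

In this assay the new step is a 4.9-fold higher number from compound 3 to compound 4 (0.69 log units; beyond the scatter), so fluoro in place of amino on an aromatic carbon runs in the opposite direction on the core of compound 3 to the one it took on the core of compound 1. The change therefore does not carry from one core to the other in this series, and the two steps differ clearly even with the earlier one known only as a floor: the same change on two cores in this assay, an at least 11-fold lower number (1.05 log units; beyond the scatter) from compound 1 to compound 2 and a 4.9-fold higher number (0.69 log units; beyond the scatter) from compound 3 to compound 4, at least 56-fold (1.74 log units) apart, beyond the scatter of two such steps

This does not show which part of the difference between the cores turns the step round, whether the sulfanyl group that stands where compound 1 has a chloro group or the rest of the core, and with one pair per core it gives no general rule; nor does it give the true size of the earlier step, since compound 1 stands at a limit of the assay: the limit of > 500000 nM in this assay, at which 1 of the 4 values shown sits.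

Open, as far as these compounds go, is how a third group at this place, such as methoxy or methylamino, would rank against amino and fluoro on either core. Also open, from the compounds shown here alone, is which direction the same change would take on a core with a methylthio group in place of the sulfanyl group.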